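The source may report more compounds than this note shows. Statements on the series, on what has been measured and on what is new or still open speak of the compounds shown alone.

Series notes on the shared core of compound 1 `CC1(C)Cc2c(sc(NC(=O)c3ccn[nH]3)c2C(N)=O)C(C)(C)O1`, varied at the group on the carbonyl carbon whose other neighbour is the amide-type nitrogen. In an assay on cells for positive allosteric modulation of Cystic fibrosis transmembrane conductance regulator variant F508del (Homo sapiens), with stated times of 10 min and 7 s, in the presence of a further agent that is not named here (a lower number here means that less compound is needed, a higher number that more compound is needed for the effect), compound 1 gives 3 nM, the lowest number of the three. Compound 2 `CC1(C)Cc2c(sc(NC(=O)C3CCNC3=O)c2C(N)=O)C(C)(C)O1` gives 101 nM in this assay and compound 3 `CC1(C)Cc2c(sc(NC(=O)C(C)(C)CO)c2C(N)=O)C(C)(C)O1` gives 75 nM; compound 3 thus stands second highest, with the step from compound 2 to compound 3 (a 1.3-fold lower number from compound 2 to compound 3 (0.13 log units; within the scatter)) within the scatter, and far from compound 1. Compound 4 `CC1(C)Cc2c(sc(NC(=O)c3[nH]ncc3Cl)c2C(N)=O)C(C)(C)O1` is not yet measured; relative to compound 3 the change is a group of 6 heavy atoms (3 carbon, 2 nitrogen, 1 chlorine; one five-membered aromatic ring with 2 hetero atoms) in place of a group of 5 heavy atoms (4 carbon, 1 oxygen; no ring), on a carbonyl carbon. The step from compound 1 to compound 2 (a 34-fold higher number from compound 1 to compound 2 (1.53 log units; beyond the scatter)) and the step from compound 1 to compound 3 (a 25-fold higher number from compound 1 to compound 3 (1.40 log units; beyond the scatter)) show that exchanging 1H-pyrazol-5-yl for a group without a ring raised the number strongly; compound 4 runs this in reverse, restoring a five-membered aromatic ring with 2 hetero atoms, here carrying chlorine. For compound 4 a large drop in this assay is therefore expected, a 15-fold lower number from compound 3 to compound 4 (1.18 log units; beyond the scatter). Compound 4 is estimated at 5 nM, range 1.5 nM to 20 nM.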

Compound 4, half-maximal effective concentration: 2 nM
Estimate against measurement, compound 4: 2.5-fold (0.40 log units) above; measured number inside the range.
By their numbers in this assay, from the lowest: compounds 4 and 1 (each within the scatter of the next); then compounds 3 and 2 (each within the scatter of the next).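

In this assay, chloro in place of hydrogen on an aromatic carbon leaves the number within the scatter (a 1.5-fold lower number from compound 1 to compound 4 (0.18 log units; within the scatter)), so this aromatic carbon of the group on the carbonyl carbon accepts a chlorine without losing the low number of compound 1. The large gap to the groups without an aromatic ring also persists with chlorine present (a 38-fold lower number from compound 3 to compound 4 (1.57 log units; beyond the scatter); a 51-fold lower number from compound 2 to compound 4 (1.70 log units; beyond the scatter)), and compound 1 and compound 4 both stand well apart from compound 2 and compound 3. Nothing on hand explains these steps.

The compounds shown leave open how a methyl, a nitrile or a carboxylic acid on that aromatic carbon would read. They also leave open whether a six-membered aromatic ring such as phenyl or pyridyl on the carbonyl carbon could match the five-membered aromatic ring.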